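Cytotoxicity notes: moving fluorines on the benzyl group

The source may report more compounds than this note shows. Statements on the series, on what has been measured and on what is new or still open speak of the compounds shown alone.

Compound 2 `CCOC(=O)/C(O)=C/C(=O)c1cn(Cc2ccc(F)c(F)c2F)c2cccc(OC)c12` gives 42700 nM in an ADME assay on MT4 cells (Homo sapiens) for cytotoxicity, read by MTT assay (a lower number here means that less compound is tolerated, a higher number that more compound is tolerated), the lowest of the two numbers shown; compound 1 `CCOC(=O)/C(O)=C/C(=O)c1cn(Cc2ccc(F)c(F)c2)c2cccc(OC)c12` gives 125000 nM. Within the data shown here, the single measured step, a 2.9-fold lower number from compound 1 to compound 2 (0.47 log units; beyond the scatter), adds a fluorine rather than moving one. Compound 3 `CCOC(=O)/C(O)=C/C(=O)c1cn(Cc2c(F)ccc(F)c2F)c2cccc(OC)c12` differs from compound 2 by 2,3,6-trifluorophenyl in place of 2,3,4-trifluorophenyl on a saturated chain carbon bound to an aromatic nitrogen. The two have the same atoms joined differently, so that step bears only loosely on it. No step beyond the scatter is expected in this assay. Compound 3 is estimated at 45000 nM, range 18000 nM to 110000 nM, which means an expected 1.1-fold higher number from compound 2 to compound 3 (0.02 log units; within the scatter).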

Compound 3, half-maximal cytotoxic concentration: 40500 nM
Compound 3: middle estimate off by 1.1-fold (0.05 log units), on the high side; measured number inside the range.
By their numbers in this assay, from the lowest: compounds 3 and 2 (each within the scatter of the next); then compound 1.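

In this assay the change to 2,3,6-trifluorophenyl from 2,3,4-trifluorophenyl gives a 1.1-fold lower number from compound 2 to compound 3 (0.02 log units; within the scatter) and so does not separate these two fluorine arrangements on a saturated chain carbon bound to an aromatic nitrogen. Set against 3,4-difluorophenyl, the 2,3,6-trifluorophenyl group gives a 3.1-fold lower number from compound 1 to compound 3 (0.49 log units; beyond the scatter) and so shows that, among these compounds, the lower number is not confined to the 2,3,4-trifluorophenyl arrangement. No evidence is available to explain either step. Still open, on these data alone, is how a chlorobenzyl or unsubstituted benzyl group would read, and whether a carboxylic acid in place of the ethyl ester would shift these numbers.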